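The source may report more compounds than this note shows. Statements on the series, on what has been measured and on what is new or still open speak of the compounds shown alone.

In an assay for inhibition of Amine oxidase [flavin-containing] B (Bos taurus), read by fluorescence, with a stated time of 60 min (on this read-out higher numbers stand for weaker inhibition and lower numbers for stronger inhibition), compound 2 `O=C(Cn1c(=O)c(Cc2ccccc2)nc2ccccc21)NNC(=O)c1ccc(Cl)cc1` gives 880000 nM, the higher of the two numbers recorded, the other belonging to compound 1 `Cc1ccc(C(=O)NNC(=O)Cn2c(=O)c(Cc3ccccc3)nc3ccccc32)cc1`, which in this assay gives 680000 nM. Among the measured compounds shown here, the step of a 1.3-fold higher number from compound 1 to compound 2 (0.11 log units; within the scatter) is the only measured step, and it is a chloro in place of a methyl on an aromatic carbon. Compound 3 `O=C(Cn1c(=O)c(Cc2ccccc2)nc2ccccc21)N/N=C/c1ccccc1` differs from compound 2 in another way: a group of 8 heavy atoms (7 carbon, 1 nitrogen; one six-membered aromatic ring of carbon only) in place of a group of 10 heavy atoms (7 carbon, 1 nitrogen, 1 oxygen, 1 chlorine; one six-membered aromatic ring of carbon only), on an amide-type nitrogen. For the measured compounds named here, no measured step touches that position, so the measured step from compound 1 to compound 2 offers no direct guide to it, and the two values on hand simply show that both compounds sit in the same weak region. With nothing to point in either direction, the number for compound 3 is expected to stay close to that of compound 2, the expected step being a 1.2-fold lower number from compound 2 to compound 3 (0.07 log units; within the scatter). Compound 3 is therefore estimated at 750000 nM, with a wide range from 200000 nM to 3000000 nM.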

Compound 3, half-maximal inhibitory concentration: 880000 nM
Compound 3: the middle estimate sits 1.2-fold (0.07 log units) below what was measured; the measured number falls inside the stated range.
By their numbers in this assay, from the lowest: compounds 1, 2 and 3 (each within the scatter of the next).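

Replacing the ((4-chlorophenyl)carbonyl)amino group on the amide-type nitrogen, which also removes its hydrogen-bond donor, gives in this assay no change at the digits printed from compound 2 to compound 3 (within the scatter) and so shows that this position tolerates the exchange without a change beyond the scatter. The same kind of exchange measured against the methyl-bearing compound gives a 1.3-fold higher number from compound 1 to compound 3 (0.11 log units; within the scatter) in this assay, so both comparisons agree that neither the chlorine nor the methyl group, nor the group that carries them, separates these compounds here. Nothing available accounts for this outcome.

As far as these compounds go, all three compounds remain in the same weak region, so it is open whether any change on this nitrogen can move the number beyond the scatter. An amine or a carboxylic acid on the aromatic ring of the entering group would test this further.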